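The source may report more compounds than this note shows. Statements on the series, on what has been measured and on what is new or still open speak of the compounds shown alone.

In a functional assay on A-431 cells (Homo sapiens) for cytotoxicity, read by MTT assay, with a stated time of 48 h (a higher number here means a weaker inhibitor, a lower number a stronger inhibitor), compound 1 `C=CC(C)(O)CC[C@@H]1C(=C)CC[C@H](Br)[C@@]1(C)CCC(O)C(C)(C)O` gives > 100000 nM, which is a limit and not a number. Compound 2 `C=CC(C)(O)CC[C@@H]1C(=C)CC[C@H](Br)[C@@]1(C)CCC(=O)C(C)C` gives > 100000 nM, which is also a limit. Compound 2 therefore offers no exact potency as a starting point, and the data so far come down to the limit of > 100000 nM in this assay, at which 2 of the 2 values shown sit. Compound 3 `C=CC(C)(O)CC[C@@H]1C(=C)CC[C@H](Br)[C@@]1(C)CCC(O)C(=C)C` has the same atoms as compound 2, joined differently: 1-hydroxy-2-methylprop-2-en-1-yl in place of isopropylcarbonyl on a saturated chain carbon, two bonds along the chain from a saturated ring carbon. Among the compounds with values here, the one measured step that bears on this change is a step that the two limits leave unreadable from compound 1 to compound 2, which alters the same place on the chain. It has no readable size to carry over, so it points in neither direction, and no shift beyond the scatter is expected in this assay. The expected change is a number no higher from compound 2 to compound 3 (the limit leaves the size open), with neither direction favoured. Compound 3 is estimated at 100000 nM, with an expected range from 30000 nM to 300000 nM.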

Compound 3, half-maximal inhibitory concentration: > 100000 nM
Compound 3: a limit, no number (the forecaster's own chance of this, stated with the estimate: 70%); the middle value sits exactly at the limit.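

Compound 3 also gives a limit and not a number, and the steps linking compound 1, compound 2 and compound 3 cannot be read. Left open in this assay is how potent any of them is, and whether the changed groups matter at all: the limit of > 100000 nM in this assay, at which 3 of the 3 values shown sit.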